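The compounds below may be only part of what the source reports. "The series", "measured", "known", "first", "only" and "open" are said of these compounds alone.

Going by the values given here, compound 3 `COc1ccc(/C=C/c2cc(=O)cco2)cc1` is one of three compounds measured in a functional assay on 786-0 cells (Homo sapiens) for inhibition, read by sulforhodamine B assay, with a stated time of 48 h; on this read-out lower numbers stand for stronger inhibition of growth and higher numbers for weaker inhibition of growth. In this assay compound 3 gives 377 uM, the second highest of the three numbers. The closest of the others is compound 2 `O=c1ccoc(/C=C/c2ccccc2)c1`, which in this assay gives 410 uM, and the furthest is compound 1 `COc1cc(/C=C/C2CC(=O)C=CO2)cc(OC)c1OC`, which in this assay gives 125 uM.

The step to compound 4 `COc1ccc(/C=C/c2cc(=O)cco2)cc1OC` changes compound 3 in one place: methoxy in place of hydrogen on an aromatic carbon. A single measured step bears on it, the same kind of change from compound 2 to compound 3, which gave a 1.1-fold lower number from compound 2 to compound 3 (0.04 log units; within the scatter). Among the compounds with values here, compound 1, with a different core and a third methoxy, sits lower, but no single step links it to compound 3, so its number only shows that more methoxy groups on this aromatic ring have gone together with a lower number once.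

On that basis the expected step from compound 3 to compound 4 is a 1.3-fold lower number from compound 3 to compound 4 (0.10 log units; within the scatter), and compound 4 is expected to give about 300 uM in this assay, with a likely range from 150 uM to 600 uM.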

Compound 4, concentration for growth inhibition (reported as GI): 635 uM
Beside the measured number, compound 4's estimate is 2.1-fold (0.33 log units) below it; measured number above the stated range.
By their numbers in this assay, from the lowest: compound 1; then compounds 3, 2 and 4 (each within the scatter of the next).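

In this assay, going by these compounds alone, a methoxy placed ortho to a methoxy group gives a 1.7-fold higher number from compound 3 to compound 4 (0.23 log units; within the scatter), so this second methoxy, like the first in the step of a 1.1-fold lower number from compound 2 to compound 3 (0.04 log units; within the scatter), cannot be told apart from repeated-measurement noise. Both steps make the same change on the same shared core, and neither gives a reliable sign that adding a methoxy to this ring shifts growth inhibition, though the position ortho to a methoxy group and meta to a group of 9 heavy atoms now has a reading of its own. No measurement here explains the size or direction of this step.

As far as these compounds go, whether an amine or a carboxylic acid at this same position would give a step beyond the scatter remains open. So does whether a longer chain in place of the methoxy would do so.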